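Shortening the hexyl chain of compound 1 to propyl

The source may report more compounds than this note shows. Statements on the series, on what has been measured and on what is new or still open speak of the compounds shown alone.

Measured compounds:
compound 1, `CCCCCCc1cn(C(c2ccccc2)c2cc3cc(Br)ccc3nc2OC)nn1`, 2.32%
compound 2, `COc1nc2ccc(Br)cc2cc1C(c1ccccc1)n1cc(-c2ccccc2F)nn1`, 13.4%
compound 3, `COc1nc2ccc(Br)cc2cc1C(c1ccccc1)n1cc(CCCO)nn1`, 14.7%

These three compounds were tested in an ADME assay on PC-3 cells (Homo sapiens) for cytotoxicity, read by sulforhodamine B assay, with a stated time of 48 h, tested at 10 uM; a higher number here means more inhibition at the concentration tested (going by the name of the read-out), a lower number less inhibition. Compound 1 stands lowest of the three values, with compound 2 nearest (a number 11.1 percentage points higher from compound 1 to compound 2 (beyond the scatter)) and compound 3 furthest (a number 12.4 percentage points higher from compound 1 to compound 3 (beyond the scatter)). The two higher values themselves sit close together (a number 1.3 percentage points higher from compound 2 to compound 3 (within the scatter)).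

Compound 4 is `CCCc1cn(C(c2ccccc2)c2cc3cc(Br)ccc3nc2OC)nn1`. It differs from compound 1 in one place: hydrogen in place of propyl on a saturated chain carbon, three bonds along the chain from an aromatic carbon. The shared core is kept and only the hexyl chain is cut back to propyl.

Two measured steps start from the same hexyl group of compound 1 and both point the same way: swapping the hexyl for a 2-fluorophenyl gave a number 11.1 percentage points higher from compound 1 to compound 2 (beyond the scatter), and swapping its terminal propyl for a hydroxy gave a number 12.4 percentage points higher from compound 1 to compound 3 (beyond the scatter). Neither step is a plain shortening, so they only suggest that moving away from the hexyl chain tends to raise the read-out. A step of similar or smaller size, toward more inhibition, is therefore expected here: a number 6.7 percentage points higher from compound 1 to compound 4 (within the scatter). Compound 4 is estimated at 9%, within a range of 0% to 20%.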

Compound 4, a percentage reported as inhibition, at one concentration (the size of the read-out at that concentration, not a potency): 8.3%
Compound 4: the middle estimate sits 0.7 percentage points above what was measured; low and high end bracket the measured number.
By their numbers in this assay, from the lowest: compounds 1, 4, 2 and 3 (each within the scatter of the next, the first and the last beyond it).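

In this assay, cutting the hexyl chain back to propyl gives a number 6 percentage points higher from compound 1 to compound 4 (within the scatter) and so, taken alone, this shortening cannot be told apart from no change at all. Compound 4 also stays close to the two compounds that stood clear of compound 1: replacing the hydroxy with hydrogen on the saturated chain carbon gives a number 6.4 percentage points lower from compound 3 to compound 4 (within the scatter) and putting propyl in place of 2-fluorophenyl gives a number 5.1 percentage points lower from compound 2 to compound 4 (within the scatter) as the result. The plain propyl compound therefore sits within the scatter of all three others, so the clear gap between compound 1 and compound 3 cannot be assigned to the shorter chain alone or to the hydroxy alone, and a 2-fluorophenyl group shows no separation from a propyl group here.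

Nothing available here explains these small differences. On these data alone, it remains open whether a methyl or ethyl group, or an amine or a carboxylic acid carried on the propyl chain, would give a number clearly separated from that of compound 4 in this assay at this position on the shared core.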